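Bromo for methoxy on the aryl arm of compound 2

A few compounds are considered here, and "the series" means these few. Any claim that something is new, unique, unknown or untested is made for them only; others in the source may bear on it.

Compound 2 `COc1cccc(/C=C/C(=O)c2c(OC)cc(OC)cc2OC)c1` gives 9400 nM in a functional assay on MCF7 cells (Homo sapiens) for cytotoxicity, with a stated time of 48 h (on this read-out lower numbers stand for stronger inhibition and higher numbers for weaker inhibition), the highest of the three numbers shown, though both other compounds lie within the scatter of it. Compound 1 `COc1cc(O)c(C(=O)/C=C/c2ccc(F)cc2)c(OC)c1` gives 8800 nM in this assay, and compound 3 `COc1cc(OC)c(C(=O)/C=C/c2ccc(Cl)cc2)c(OC)c1` gives 7500 nM. Compound 4 `COc1cc(OC)c(C(=O)/C=C/c2ccc(Br)cc2)c(OC)c1` differs from compound 2 by 4-bromophenyl in place of 3-methoxyphenyl on a double-bonded chain carbon bound to a double-bonded chain carbon. For the measured compounds named here, the one single-place step that bears on this is the exchange to 4-chlorophenyl, a 1.3-fold lower number from compound 2 to compound 3 (0.10 log units; within the scatter), which stayed within the scatter. Because a 1.3-fold lower number from compound 2 to compound 3 (0.10 log units; within the scatter) stayed within the scatter, no step beyond the scatter is expected in this assay for the 4-bromophenyl exchange either, and the expected step is a 1.3-fold lower number from compound 2 to compound 4 (0.10 log units; within the scatter). Compound 4 is therefore estimated at 7500 nM, with a range from 3700 nM to 15000 nM.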

Compound 4, half-maximal inhibitory concentration: 9500 nM
Compound 4: the middle estimate sits 1.3-fold (0.10 log units) below what was measured; low and high end bracket the measured number.
By their numbers in this assay, from the lowest: compounds 3, 1, 2 and 4 (each within the scatter of the next).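

The exchange to 4-bromophenyl gives a 1.0-fold higher number from compound 2 to compound 4 (0.00 log units; within the scatter) in this assay, so a second halogen-bearing aryl arm also produces no step beyond the scatter at this place. Bromo in place of chloro on the aromatic carbon gives a 1.3-fold higher number from compound 3 to compound 4 (0.10 log units; within the scatter) and so does not separate the two halogens in this assay.

Still open, from the compounds shown here alone, is whether a different substituent on the aryl arm, such as an amine or a carboxylic acid, would produce a step beyond the scatter. No measurement in hand bears on why these steps remain within the scatter.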